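Adding a Two-Carbon Link to Compound 2

The source may report more compounds than this note shows. Statements on the series, on what has been measured and on what is new or still open speak of the compounds shown alone.

Measured so far in a physicochemical assay for lipophilicity, using the shake flask method, measured as octanol-water partition, at pH 7.4; on this read-out lower numbers stand for lower lipophilicity and higher numbers for higher lipophilicity:
- compound 1 `CC(=O)N1CCC(c2cc3c(-c4ccc(=O)n(C(C)C)c4)ccnc3[nH]2)CC1` gives 2.1
- compound 2 `CN(C)C(=O)CN1CCC(c2cc3c(-c4ccc(=O)n(C5CCOCC5)c4)ccnc3[nH]2)CC1` gives 1.1

Of these two compounds, compound 2 has the lower number at 1.1, and the gap up to compound 1 lies beyond the usual scatter. The two differ in more than one place, so their gap cannot be tied to any single change. The next compound, compound 3 `CN(C)C(=O)CN1CCC(c2cc3c(-c4ccc(=O)n(CCC5CCOCC5)c4)ccnc3[nH]2)CC1`, differs from compound 2 in one place only: 2-(oxan-4-yl)ethyl in place of oxan-4-yl on an aromatic nitrogen. In words, this is 2-(oxan-4-yl)ethyl in place of oxan-4-yl on an aromatic nitrogen. Among the compounds with values here, no measured pair shows this change on its own, so the forecast is a judgement. A modest rise in this assay is expected, slightly beyond the scatter. The expected step is a number 0.50 log units higher from compound 2 to compound 3 (beyond the scatter). Compound 3 is estimated at 1.6, with an expected range from 1.2 to 2.1.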

Compound 3, distribution coefficient: 1.5
The estimate for compound 3 lay 0.10 log units above the measured number; measured number inside the range.
By their numbers in this assay, from the lowest: compound 2; then compound 3; then compound 1.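

In this assay, replacing oxan-4-yl with 2-(oxan-4-yl)ethyl on the aromatic nitrogen gives a number 0.40 log units higher from compound 2 to compound 3 (beyond the scatter), so a change at this position alone is enough to move the number beyond the scatter. The earlier compounds shown here differed in more than one place and could not show this. The ring and the hydrogen-bond acceptor count stay the same in both groups while the heavy atoms go from 6 to 8, but no measurement shown gives a reason for the step.

Still open, as far as these compounds go, is whether a longer chain on the same nitrogen would raise the number again, and what an amine or a carboxylic acid in place of the oxan-4-yl ring would do. One step also cannot show whether this change would give a similar rise on a different core.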